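The compounds below may be only part of what the source reports. "The series", "measured", "known", "first", "only" and "open" are said of these compounds alone.

Measured so far:
compound 1 `CNCc1cc(-c2cccnc2F)n(S(=O)(=O)c2cccs2)c1` gives -0.69 in a physicochemical assay for lipophilicity, read by HPLC, at pH 7.4; a higher number here means a more lipophilic compound, a lower number a more polar compound
compound 2 `CNCc1cn(S(=O)(=O)c2cc(OC)ccn2)c(-c2cccnc2F)c1F` gives 0.51 in this assay

Compound 2 stands highest of the two numbers; its nearest neighbour, compound 1, sits lower by a gap that is beyond the scatter. The step to compound 3 `CNCc1cn(S(=O)(=O)c2cnccc2C)c(-c2cccnc2F)c1F` changes the ring on the sulfonyl sulfur: 4-methylpyridin-3-yl in place of 4-methoxypyridin-2-yl on a sulfonyl sulfur. Among the measured compounds shown here, no step between two measured compounds matches this swap, so the expectation leans only on the shape of the change, which keeps one six-membered aromatic ring with one hetero atom and drops one hydrogen-bond acceptor. A small upward move, within the scatter, is expected: a number 0.19 log units higher from compound 2 to compound 3 (within the scatter). Compound 3 is therefore estimated at 0.7, in the range 0.2 to 1.2.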

Compound 3, distribution coefficient: 0.43
Compound 3: the middle estimate sits 0.27 log units above what was measured, and the stated range covers the measured number.
By their numbers in this assay, from the lowest: compound 1; then compounds 3 and 2 (each within the scatter of the next).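

On a sulfonyl sulfur, this assay reads a number 0.08 log units lower from compound 2 to compound 3 (within the scatter) when 4-methylpyridin-3-yl takes the place of 4-methoxypyridin-2-yl. This swap drops one hydrogen-bond acceptor and still gives no change beyond the scatter, something compound 1 could not show, since it differs from compound 2 in more than one place. Nothing measured here offers a reason for this. Open, on these data alone, is whether the number would hold with a very different group on the sulfonyl sulfur, such as a phenyl ring carrying a carboxylic acid or an amine.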